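Aryl hydrazone series: 2-cyanophenyl replaced by 4-(trifluoromethyl)phenyl

The source may report more compounds than this note shows. Statements on the series, on what has been measured and on what is new or still open speak of the compounds shown alone.

Measured so far in an assay on CHO-K1 cells for displacement of a labelled ligand from adenosine receptor A1 (Homo sapiens), read by scintillation counting, with a stated time of 60 min; on this read-out lower numbers stand for stronger inhibition and higher numbers for weaker inhibition:
compound 1 `CCOc1cc(/C=N/Nc2nc(N)c3ncn([C@@H]4O[C@H](CO)[C@@H](O)[C@H]4O)c3n2)ccc1O` gives 6940 nM
compound 2 `N#Cc1ccccc1/C=N/Nc1nc(N)c2ncn([C@@H]3O[C@H](CO)[C@@H](O)[C@H]3O)c2n1` gives 2.9 nM
compound 3 `Nc1nc(N/N=C/c2ccc(N(c3ccccc3)c3ccccc3)cc2)nc2c1ncn2[C@@H]1O[C@H](CO)[C@@H](O)[C@H]1O` gives only a limit of the assay, > 10000 nM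

Compound 2 holds the lowest of the two numbers shown; its nearest neighbour is compound 1, and the step of a 2400-fold lower number from compound 1 to compound 2 (3.38 log units; beyond the scatter) separates them. The value for compound 3 is a limit of this assay and not a number (the limit of > 10000 nM in this assay, at which 1 of the 3 values shown sits).

Compound 4 `Nc1nc(N/N=C/c2ccc(C(F)(F)F)cc2)nc2c1ncn2[C@@H]1O[C@H](CO)[C@@H](O)[C@H]1O` differs from compound 2 in one place: 4-(trifluoromethyl)phenyl in place of 2-cyanophenyl on a carbon with a double bond to nitrogen. Among the compounds with values here, only one measured step bears on this change, a 2400-fold lower number from compound 1 to compound 2 (3.38 log units; beyond the scatter), and it was large; it shows that what stands on the carbon with a double bond to nitrogen decides the outcome in this assay across more than the whole span of the measured numbers. Compound 4 carries a 4-(trifluoromethyl)phenyl rather than the 2-cyanophenyl of compound 2, and the other aryl groups measured, in compound 1 and compound 3, both gave markedly weaker results than compound 2. A sizeable rise is therefore expected, though smaller than the full step from compound 1. The step of a 100-fold higher number from compound 2 to compound 4 (2.01 log units; beyond the scatter) is the expected size of that rise. Compound 4 is estimated at 300 nM, with a range from 30 nM to 3000 nM.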

Compound 4, inhibition constant: 37 nM
Compound 4: the middle estimate sits 8.1-fold (0.91 log units) above what was measured; the measured number falls inside the stated range.
By their numbers in this assay, from the lowest: compound 2; then compound 4; then compound 1. At a limit, above all of these: compound 3.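

In this assay, a low number at this position does not depend on 2-cyanophenyl alone: replacing 3-ethoxy-4-hydroxyphenyl with 4-(trifluoromethyl)phenyl gives a 190-fold lower number from compound 1 to compound 4 (2.27 log units; beyond the scatter), while the replacement of 2-cyanophenyl by the same group gives a 13-fold higher number from compound 2 to compound 4 (1.11 log units; beyond the scatter), so 2-cyanophenyl remains the better of these two groups and compound 4 lies clearly between compound 2 and compound 1. The group entering at this carbon counts no hydrogen-bond acceptor, whereas 2-cyanophenyl counts one, so a nitrile is not required for compound 4 to reach a number far lower than that of compound 1. The change alters both the substituent and its place on the phenyl, and no measured property of either group accounts for these steps.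

The compounds shown contain no pair with the same substituent at two places on the phenyl, so the effect of the group and the effect of its place cannot yet be separated. Also open, on these data alone, is where an unsubstituted phenyl, or a phenyl carrying an amine or a carboxylic acid, would stand at this carbon in this assay.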